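Primary amide to hydroxyazetidine amide on the shared core

This account rests on a few compounds, and the source may have more. Where it says the series, first, only, none or still open, it means among the compounds named here.

Of the compounds shown here, two carry numbers so far. Compound 1 `CC1(OC(=O)N2CCC3(CC2)CC(CCCOc2ccc(S(C)(=O)=O)c(F)c2)C3)CC1` in a functional assay on cells for agonist activity at Glucose-dependent insulinotropic receptor (Homo sapiens), read by HTRF and cAMP accumulation, with a stated time of 30 min (on this read-out lower numbers stand for an effect already at smaller amounts and higher numbers for an effect only at larger amounts of compound), gives 13 nM. Compound 2 `CC(C)OC(=O)N1CCC2(CC1)CC(CCCOc1ccc(C(N)=O)c(F)c1)C2` in this assay gives 52 nM. Compound 2 therefore stands at the higher of the two numbers; the gap to compound 1 lies beyond the usual scatter, but the two compounds differ in more than one place, so the gap is not tied to any single structural step.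

Compound 3 `CC(C)OC(=O)N1CCC2(CC1)CC(CCCOc1ccc(C(=O)N3CC(O)C3)c(F)c1)C2` is not yet measured. Relative to compound 2 the change is 3-hydroxyazetidin-1-yl in place of amino on a carbonyl carbon, in words 3-hydroxyazetidin-1-yl in place of amino on a carbonyl carbon. Going by the values given here, no measured pair shows this change, so there is no reference step for its size. The expectation is a step that stays close to the scatter, with no firm direction.

Compound 3 is expected to give 45 nM in this assay, with a range from 12 nM to 160 nM. This estimate means an expected step of a 1.2-fold lower number from compound 2 to compound 3 (0.06 log units; within the scatter), which is not expected to exceed the scatter.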

Compound 3, half-maximal effective concentration: 40 nM
The estimate for compound 3 lay 1.1-fold (0.05 log units) above the measured number, and the stated range covers the measured number.
By their numbers in this assay, from the lowest: compound 1; then compounds 3 and 2 (each within the scatter of the next).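

The series now has its first step at this position: in this assay, 3-hydroxyazetidin-1-yl in place of amino on a carbonyl carbon gives a 1.3-fold lower number from compound 2 to compound 3 (0.11 log units; within the scatter). A group of 5 heavy atoms with a four-membered non-aromatic ring therefore stands here in place of a group of 1 heavy atom, with no change beyond the scatter, so the read-out at this position does not depend on keeping the primary amide, at least for this one pair on the shared core. No measured information on hand says why the number holds through this change.

The compounds shown leave open whether the hydroxyl of the azetidine contributes anything, which a plain azetidin-1-yl on the same carbonyl carbon would test, and how a larger ring such as 3-hydroxypyrrolidin-1-yl, an open-chain dimethylamino group or a carboxylic acid would read there. They also leave open whether this step carries over to the other end of the series, as compound 1 differs from both compound 2 and compound 3 in more than one place and offers no single-change comparison.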